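A few compounds are considered here, and "the series" means these few. Any claim that something is new, unique, unknown or untested is made for them only; others in the source may bear on it.

Compound 1: `Cc1ccc(S(=O)(=O)NCc2ccc(CNC(=O)c3ccccc3)cc2)cc1`
In an assay on MDA-MB-231 cells for binding affinity to C-X-C chemokine receptor type 4 (Homo sapiens), read by immunofluorescence and microscopy, with stated times of 10 min and 30 min (on this read-out lower numbers stand for an effect already at smaller amounts and higher numbers for an effect only at larger amounts of compound), compound 1 gives > 1000 nM, which is a limit of the assay rather than a number.
Compound 2: `COc1cccc(C(=O)NCc2ccc(CNS(=O)(=O)c3ccc(C)cc3)cc2)c1`
In this assay compound 2 gives 10 nM.

Compound 2 thus holds the only number shown in this assay; the other value is a limit (the limit of > 1000 nM in this assay, at which 1 of the 2 values shown sits). Among the measured compounds shown here, the one measured step, an at least 100-fold lower number from compound 1 to compound 2 (2.00 log units; beyond the scatter), is methoxy in place of hydrogen on an aromatic carbon, and it is large. Compound 3, `COc1ccc(C(=O)NCc2ccc(CNS(=O)(=O)c3ccc(C)cc3)cc2)cc1`, is not yet measured; it differs from compound 2 by 4-methoxyphenyl in place of 3-methoxyphenyl on a carbonyl carbon. For the measured compounds named here, no measured step changes the place of the methoxy group, so nothing here says directly how this assay will answer. The step of an at least 100-fold lower number from compound 1 to compound 2 (2.00 log units; beyond the scatter) shows that the methoxy group in compound 2 carries much of the effect, so moving it brings real uncertainty. Compound 3 is therefore expected to give a somewhat higher number, a 4.0-fold higher number from compound 2 to compound 3 (0.60 log units; beyond the scatter). Compound 3 is estimated at 40 nM, within 8 nM to 300 nM.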

Compound 3, effective concentration (reported as EC, without a stated level of effect): 100 nM
Beside the measured number, compound 3's estimate is 2.5-fold (0.40 log units) below it, and the stated range covers the measured number.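

In this assay compounds 2 and 3 hold the same atoms, so moving the methoxy group alone gives a 10-fold higher number from compound 2 to compound 3 (1.00 log units; beyond the scatter), which shows that its place on the ring counts and not only its presence. Methoxy in place of hydrogen still pays in the new place, with an at least 10-fold lower number from compound 1 to compound 3 (1.00 log units; beyond the scatter), so the gain over the unsubstituted compound is not confined to the 3-methoxyphenyl group. Both steps from compound 1 are bounds only, because its value is a limit and not a number: the limit of > 1000 nM in this assay, at which 1 of the 3 values shown sits.

Going by these compounds, it remains open whether an ethoxy group or a fluorine in place of methoxy would keep the lower number of compound 2. Also open, on these data alone, is whether an amine on this ring would follow the same order between the two places.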